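This account rests on a few compounds, and the source may have more. Where it says the series, first, only, none or still open, it means among the compounds named here.

In a functional assay on A2780 cells (Homo sapiens) for antiproliferative activity, read by fluorescence, with a stated time of 72 h (a lower number here means a stronger inhibitor, a higher number a weaker inhibitor), compound 1 `CN1CCC(C(=O)N2Cc3c(NC(=O)Nc4cccc(F)c4)n[nH]c3C2(C)C)CC1` gives 350 nM. For the measured compounds named here, compound 2 `CN1CCC(C(=O)N2Cc3c(NC(=O)c4ccccc4)n[nH]c3C2(C)C)CC1`, in which phenyl stands in place of (3-fluorophenyl)amino on the carbonyl carbon, gives 160 nM in this assay, and the change a 2.2-fold lower number from compound 1 to compound 2 (0.34 log units; beyond the scatter) is the only measured step. Compound 2 thus holds the lower of the two numbers, with compound 1 its nearest neighbour. Compound 3 `CN1CCC(C(=O)N2Cc3c(NC(=O)c4cccc(F)c4)n[nH]c3C2(C)C)CC1` differs from compound 2 by fluoro in place of hydrogen on an aromatic carbon. Going by the values given here, no measured step isolates this change: the single step between compound 1 and compound 2 swaps the whole (3-fluorophenyl)amino group for phenyl, so the fluorine and the amino link move together and the fluoro alone cannot be read from it. One therefore expects no step beyond the scatter, and the estimated change is no change at the digits printed from compound 2 to compound 3 (within the scatter). Compound 3 is expected to give 160 nM, within a range from 70 nM to 360 nM.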

Compound 3, half-maximal inhibitory concentration: 200 nM
Beside the measured number, compound 3's estimate is 1.3-fold (0.10 log units) below it; low and high end bracket the measured number.
By their numbers in this assay, from the lowest: compounds 2, 3 and 1 (each within the scatter of the next, the first and the last beyond it).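

In this assay, fluoro in place of hydrogen on this aromatic carbon, meta to a large group, can now be read on its own: it gives a 1.3-fold higher number from compound 2 to compound 3 (0.10 log units; within the scatter) and so cannot be told apart from hydrogen at this position. With the 3-fluorophenyl kept, replacing the (3-fluorophenyl)amino group on the carbonyl carbon gives a 1.8-fold lower number from compound 1 to compound 3 (0.24 log units; within the scatter), so the amino link alone also stays within the scatter, whereas the earlier step, a 2.2-fold lower number from compound 1 to compound 2 (0.34 log units; beyond the scatter), changed the link and the fluorine together. No evidence is at hand that bears on these results.

As far as these compounds go, whether chloro, methoxy or an amine on this same carbon would separate from hydrogen remains open. So does fluoro on the other carbons of the ring.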